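The source may hold more compounds than are shown below. What is called first, only, known or untested is meant among the compounds shown, and "the series" means these compounds.

Compound 2 `COc1ccccc1N1CCN(CCCCCC(=O)N2Cc3ccccc3C[C@H]2C(N)=O)CC1` gives 302 nM in an assay on HEK293 cells for displacement of a labelled ligand from 5-hydroxytryptamine receptor 7 (Homo sapiens), with a stated time of 1 h (on this read-out lower numbers stand for stronger inhibition and higher numbers for weaker inhibition), the highest of the two numbers recorded so far; its nearest neighbour, compound 1 `NC(=O)[C@@H]1CCCN1C(=O)CCCCCN1CCN(c2noc3ccccc23)CC1`, gives 50 nM in this assay, a gap beyond the usual scatter. Compound 3 `NC(=O)[C@@H]1Cc2ccccc2CN1C(=O)CCCCCN1CCN(c2noc3ccccc23)CC1` arises from compound 2 by a group of 9 heavy atoms (7 carbon, 1 nitrogen, 1 oxygen; one five-membered aromatic ring with 2 hetero atoms, one six-membered aromatic ring of carbon only) in place of a group of 8 heavy atoms (7 carbon, 1 oxygen; one six-membered aromatic ring of carbon only), on an amine nitrogen in a ring. Within the data shown here, no measured pair isolates this change, but compound 3 carries the same group on the ring amine as compound 1, which gives 50 nM in this assay. Compound 3 is therefore expected to show a lower number, with a step of a 3.8-fold lower number from compound 2 to compound 3 (0.58 log units; beyond the scatter) beyond the scatter. The estimate for compound 3 in this assay is 80 nM, ranging from 25 nM to 250 nM.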

Compound 3, inhibition constant: 22 nM
For compound 3 the middle estimate is 3.6-fold (0.56 log units) above the measured one, outside the stated range (below it).
By their numbers in this assay, from the lowest: compound 3; then compound 1; then compound 2.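

In this assay, putting the group with a five-membered aromatic ring with 2 hetero atoms in place of 2-methoxyphenyl on the ring amine nitrogen gives a 14-fold lower number from compound 2 to compound 3 (1.14 log units; beyond the scatter). This pair isolates the change at this position, which the two earlier compounds, differing in more than one place, could not do. No measured evidence here accounts for the size of this step. As far as these compounds go, how a plain phenyl or a pyridine ring would stand on this nitrogen remains open. So does whether a longer chain would keep the low number of compound 3.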